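Amide nitrogen substituents on a chromone acrylamide series

The source may hold more compounds than are shown below. What is called first, only, known or untested is meant among the compounds shown, and "the series" means these compounds.

Measured so far:
compound 1 `COc1ccc2c(=O)c(/C=C/C(=O)Nc3cccc(Cl)c3)coc2c1` — 470 nM
compound 2 `COc1ccc2c(=O)c(/C=C/C(=O)NCc3ccccc3F)coc2c1` — > 100000 nM
compound 3 `COc1ccc2c(=O)c(/C=C/C(=O)Nc3ccccc3OC)coc2c1` — > 100000 nM

In a functional assay on A549 cells (Homo sapiens) for inhibition, read by MTT assay, with a stated time of 48 h (on this read-out higher numbers stand for weaker inhibition and lower numbers for stronger inhibition), compound 1 gives 470 nM. For compound 2 this assay reports only a limit, > 100000 nM. For compound 3 likewise only a limit is reported, > 100000 nM; compound 3 therefore stands at the edge of what this assay can read, together with compound 2, as noted in the limit of > 100000 nM in this assay, at which 2 of the 3 values shown sit. The steps from compound 1 are an at least 210-fold higher number from compound 1 to compound 2 (2.32 log units; beyond the scatter) and an at least 210-fold higher number from compound 1 to compound 3 (2.32 log units; beyond the scatter), while the step that the two limits leave unreadable from compound 2 to compound 3.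

Compound 4 `COc1ccc2c(=O)c(/C=C/C(=O)NCc3ccc(F)cc3F)coc2c1` remains to be measured. It differs from compound 3 in one place: 2,4-difluorobenzyl in place of 2-methoxyphenyl on an amide-type nitrogen. The step that bears most directly on this change is an at least 210-fold higher number from compound 1 to compound 2 (2.32 log units; beyond the scatter), since compound 2 carries a 2-fluorobenzyl on the same nitrogen and sits at the limit; compound 4 carries a 2,4-difluorobenzyl there. Both compound 2 and compound 3 sitting at the limit leaves the direction of a step that the two limits leave unreadable from compound 2 to compound 3 open, so no movement beyond the scatter is expected in this assay from compound 3 to compound 4; the expected step is a number no higher from compound 3 to compound 4 (the limit leaves the size open). Compound 4 is accordingly estimated at 100000 nM, within 20000 nM to 300000 nM, most probably reported again only as a limit.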

Compound 4, half-maximal inhibitory concentration: 13300 nM
Compound 4: the middle estimate sits 7.5-fold (0.88 log units) above what was measured, outside the stated range (below it).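

In this assay, a benzyl group on the amide-type nitrogen does not by itself put a compound at the limit: the one added fluoro gives an at least 7.5-fold lower number from compound 2 to compound 4 (0.87 log units; beyond the scatter). Replacing 2-methoxyphenyl with 2,4-difluorobenzyl gives an at least 7.5-fold lower number from compound 3 to compound 4 (0.87 log units; beyond the scatter), yet the 3-chlorophenyl group still reads better than 2,4-difluorobenzyl on this nitrogen, with a 28-fold higher number from compound 1 to compound 4 (1.45 log units; beyond the scatter). Both lower steps start from a limit, so they give only a minimum size: the limit of > 100000 nM in this assay, at which 2 of the 4 values shown sit.

The step between compound 2 and compound 3 cannot be read, so those two compounds do not rank 2-fluorobenzyl against 2-methoxyphenyl. The compounds shown also leave open how an unsubstituted benzyl group, a longer phenethyl chain or a morpholine would read on this nitrogen, and whether any of them would come closer to the 3-chlorophenyl group or fall back to the limit.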